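Shifting the trifluoromethyl group around the benzyl ether ring

The source may report more compounds than this note shows. Statements on the series, on what has been measured and on what is new or still open speak of the compounds shown alone.

compound 1, `COc1cc(OC)c(-c2coc3cc(OCc4ccc(Br)cc4)ccc3c2=O)cc1OC`: 1050 nM
compound 2, `COc1cc(OC)c(-c2coc3cc(OCc4ccc(Cl)cc4)ccc3c2=O)cc1OC`: 940 nM
compound 3, `COc1cc(OC)c(-c2coc3cc(OCc4ccc(C(F)(F)F)cc4)ccc3c2=O)cc1OC`: 890 nM

In a functional assay on HepG2 cells (Homo sapiens) for antiproliferative activity, read by MTT assay, with a stated time of 24 h (on this read-out higher numbers stand for weaker inhibition and lower numbers for stronger inhibition), compound 1 gives the highest of the three numbers, but its steps to the other two, a 1.1-fold lower number from compound 1 to compound 2 (0.05 log units; within the scatter) and a 1.2-fold lower number from compound 1 to compound 3 (0.07 log units; within the scatter), both sit within the scatter, so the three compounds cannot be told apart on these data. Compound 4, `COc1cc(OC)c(-c2coc3cc(OCc4cccc(C(F)(F)F)c4)ccc3c2=O)cc1OC`, has not yet been measured. It differs from compound 1 in one place: 3-(trifluoromethyl)phenyl in place of 4-bromophenyl on a saturated chain carbon bound to an oxygen on an aromatic ring. Of the measured steps, the one most closely related is a 1.2-fold lower number from compound 1 to compound 3 (0.07 log units; within the scatter), which put trifluoromethyl in place of bromo at the same ring position and stayed within the scatter, as did a 1.1-fold lower number from compound 2 to compound 3 (0.02 log units; within the scatter). Among the measured compounds shown here, no measured pair differs only in where the substituent sits on the benzyl ring, so the effect of moving it is unknown. The step of a 1.1-fold lower number from compound 1 to compound 4 (0.04 log units; within the scatter) is therefore expected to be small, with no direction beyond the scatter. Compound 4 is estimated at 950 nM, within a range from 400 nM to 2300 nM.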

Compound 4, half-maximal inhibitory concentration: 610 nM
Compound 4: the middle estimate sits 1.6-fold (0.19 log units) above what was measured; the range from low to high includes it.
By their numbers in this assay, from the lowest: compounds 4, 3, 2 and 1 (each within the scatter of the next).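

Moving the trifluoromethyl group gives the first pair here that differs only in where the substituent sits on the benzyl ring, and in this assay that step stays within the scatter (a 1.5-fold lower number from compound 3 to compound 4 (0.16 log units; within the scatter)). The steps that change the group and its place together also stay within the scatter (a 1.7-fold lower number from compound 1 to compound 4 (0.24 log units; within the scatter); a 1.5-fold lower number from compound 2 to compound 4 (0.19 log units; within the scatter)), so on these data 3-(trifluoromethyl)phenyl cannot be told apart from 4-bromophenyl, 4-chlorophenyl or 4-(trifluoromethyl)phenyl at this place. Nothing available on these compounds speaks to what lies behind these steps.

The compounds shown leave open whether an amine or a carboxylic acid on this benzyl ring would give a step beyond the scatter. They also leave open whether a longer chain in place of the benzyl carbon would do so.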